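From 2,4-dimethylphenyl to 3-carboxypyridin-2-yl on a sulfur

The compounds below may be only part of what the source reports. "The series", "measured", "known", "first", "only" and "open" are said of these compounds alone.

In a functional assay on HCT-116 cells (Homo sapiens) for antiproliferative activity, read by MTT assay, with a stated time of 72 h (on this read-out higher numbers stand for weaker inhibition and lower numbers for stronger inhibition), compound 2 `Cc1ccc(SCC(=O)Nc2ccc3nc(NC(=O)c4ccc(C(F)(F)F)cc4)sc3c2)c(C)c1` gives 320 nM, the lower of the two actual numbers in this small set. The other number belongs to compound 1 `O=C(CSc1nc2ccccc2[nH]1)Nc1ccc2nc(NC(=O)c3ccc(C(F)(F)F)cc3)sc2c1`, at 3760 nM. Compound 3 `O=C(CSc1nnc(NC(=O)COc2ccccc2)s1)Nc1ccc(Br)cc1` gives > 100000 nM, which is a limit of the assay and not a number.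

Compound 4 `O=C(CSc1ncccc1C(=O)O)Nc1ccc2nc(NC(=O)c3ccc(C(F)(F)F)cc3)sc2c1` carries 3-carboxypyridin-2-yl in place of 2,4-dimethylphenyl on a sulfur. For the measured compounds named here, one measured step bears on this place, a 12-fold lower number from compound 1 to compound 2 (1.07 log units; beyond the scatter), with 2,4-dimethylphenyl in place of 1H-benzimidazol-2-yl on a sulfur. Going by the values given here, compound 4 also gives up the ring of carbon only, this time for a ring with a hetero atom, so that large step is taken as a guide when read backwards, though the entering group differs from the one in compound 1. In this assay a similar rise is therefore expected, estimated as a 13-fold higher number from compound 2 to compound 4 (1.10 log units; beyond the scatter). For compound 4 the estimate is 4000 nM, with an expected range of 1000 nM to 25000 nM.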

Compound 4, half-maximal inhibitory concentration: 2300 nM
Compound 4: middle estimate off by 1.7-fold (0.24 log units), on the high side; the measured number falls inside the stated range.
By their numbers in this assay, from the lowest: compound 2; then compounds 4 and 1 (each within the scatter of the next). At a limit, above all of these: compound 3.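

In this assay, the change on this sulfur from a ring of carbon only to a ring with a hetero atom now has a second example, with a 7.2-fold higher number from compound 2 to compound 4 (0.86 log units; beyond the scatter) lying beyond the scatter. The two rings with hetero atoms cannot be told apart, since a 1.6-fold lower number from compound 1 to compound 4 (0.21 log units; within the scatter) stays within the scatter even though 3-carboxypyridin-2-yl and 1H-benzimidazol-2-yl are otherwise quite different groups. Among the three compounds that share this core, compound 2, the only one with a ring of carbon only on this sulfur, therefore holds the lowest number, with no compound going against this.

The compounds shown do not separate the ring nitrogen from the carboxylic acid, which a plain pyridin-2-yl or a phenyl ring carrying a carboxylic acid could do. Nothing measured here speaks to the cause of these steps.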